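Three sulfonamides at the assay limit, a fourth expected

This account rests on a few compounds, and the source may have more. Where it says the series, first, only, none or still open, it means among the compounds named here.

Measured so far in an assay on isolated protein for inhibition of malate dehydrogenase, mitochondrial (Sus scrofa), with stated times of 45 min and 30 min; on this read-out lower numbers stand for stronger inhibition and higher numbers for weaker inhibition:
Compound 1, `Cc1ccccc1S(=O)(=O)Nc1ccc2oc(-c3ccccc3)nc2c1`: > 63000 nM
Compound 2, `O=S(=O)(Nc1ccc2oc(-c3ccccc3)nc2c1)c1ccc(F)c(C(F)(F)F)c1`: > 63000 nM
Compound 3, `O=S(=O)(Nc1ccc(-c2nc3ccccc3o2)cc1)c1ccccc1F`: > 63000 nM.

For compound 1 the value is a limit of this assay and not a number. The same holds for compound 2. The same holds for compound 3. the limit of > 63000 nM in this assay, at which 3 of the 3 values shown sit, sums the record up: none of the three has shown inhibition within the measurable range. Going by the values given here, compound 1 therefore cannot be placed above or below the other two; it sits at the limit together with them, and no step between measured compounds can be drawn.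

Compound 4, `O=S(=O)(Nc1ccc2oc(-c3ccccc3)nc2c1)c1cccc(Cl)c1`, differs from compound 1 in one place: 3-chlorophenyl in place of 2-methylphenyl on a sulfonyl sulfur. Among the compounds with values here, with no measured step to go by and three limits as the whole record, no shift beyond the usual scatter is expected in this assay in either direction. Compound 4 is therefore expected to give 70000 nM, within a range from 30000 nM to 200000 nM, most likely once more as a limit rather than a number. This estimate implies a step that the limit leaves unreadable from compound 1 to compound 4, which is expected to mean no change beyond the scatter.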

Compound 4, half-maximal inhibitory concentration: > 63000 nM
Compound 4 ended at the assay's limit (the forecaster's own chance of this, stated with the estimate: 85%); the middle value is on the limit's open side.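

In this assay compound 1 and compound 4 both stand as limits and not as numbers, and no step can be read between them. The compounds shown leave open whether any change to the group on the sulfonyl sulfur or to the shared core would bring inhibition into the measurable range.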